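This account rests on a few compounds, and the source may have more. Where it says the series, first, only, none or still open, it means among the compounds named here.

Compound 1 `Cc1nn(C)c(Oc2ccc(F)cc2)c1/C=N\OCc1c(Cl)c(-c2ccc(F)cc2)nn1C` gives 6640 nM in a functional assay on SMMC-7721 cells (Homo sapiens) for antiproliferative activity, read by MTT assay, with a stated time of 72 h (a higher number here means a weaker inhibitor, a lower number a stronger inhibitor), and compound 2 `Cc1nn(C)c(Oc2ccc(F)cc2)c1/C=N\OCc1c(Cl)c(-c2ccc(Cl)cc2)nn1C` gives 3230 nM in this assay, the lowest of the two numbers. Going by the values given here, the only measured step, a 2.1-fold lower number from compound 1 to compound 2 (0.31 log units; beyond the scatter), concerns chloro in place of fluoro and not the change now at hand. Compound 3 `Cc1nn(C)c(Oc2ccc(OC(F)(F)F)cc2)c1/C=N\OCc1c(Cl)c(-c2ccc(Cl)cc2)nn1C` differs from compound 2 by trifluoromethoxy in place of fluoro on an aromatic carbon. Among the compounds with values here, no measured step touches this change, so the record offers little guidance. For compound 3 a shift no larger than modest is expected, a 1.3-fold lower number from compound 2 to compound 3 (0.11 log units; within the scatter). Compound 3 is therefore estimated at 2500 nM, with a range from 800 nM to 8000 nM.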

Compound 3, half-maximal inhibitory concentration: 8670 nM
Compound 3: middle estimate off by 3.5-fold (0.54 log units), on the low side, outside the stated range (above it).
By their numbers in this assay, from the lowest: compound 2; then compounds 1 and 3 (each within the scatter of the next).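

Going from 4-fluorophenoxy to 4-(trifluoromethoxy)phenoxy weakens activity in this assay, with a 2.7-fold higher number from compound 2 to compound 3 (0.43 log units; beyond the scatter). Going by these compounds alone, the earlier step changed a halogen elsewhere in the molecule, so this is the first sign that the phenoxy substituent also affects the number, and that trifluoromethoxy does worse here than fluoro. Nothing at hand explains this loss. On these data alone, whether a methoxy group, an amine or a carboxylic acid at this place would match fluoro remains open. So does whether the same change would cost as much alongside the 4-fluorophenyl group of compound 1.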